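This account rests on a few compounds, and the source may have more. Where it says the series, first, only, none or still open, it means among the compounds named here.

The three measured compounds:

Compound 1 `COc1ccc(-c2cc(/C=C/C(=O)c3ccc(N)cc3)[nH]n2)cc1` gives 50% in a functional assay on HCT-15 cells (Homo sapiens) for cytotoxicity, read by sulforhodamine B assay, with a stated time of 48 h, tested at 1 uM; a higher number here means a weaker effect of the compound at the concentration tested, a lower number a stronger effect.
Compound 2 `COc1ccc(-c2cc(/C=C/C(=O)c3ccc(N)cc3)[nH]n2)cc1OC` gives 73% in this assay.
Compound 3 `COc1cc(C(=O)/C=C/c2cc(-c3cc(OC)c(OC)c(OC)c3)n[nH]2)cc(OC)c1OC` gives 76% in this assay.

Compound 1 and compound 2 differ in one place only, by hydrogen in place of methoxy on an aromatic carbon. In this assay this change made a step of a number 23 percentage points lower from compound 2 to compound 1 (beyond the scatter), that is, the compound without the methoxy group acted more strongly on the cells at the tested concentration.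

Compound 3 carries the highest number of the three. Its value and that of compound 2 lie within the usual scatter of each other, so no order between them can be read. The difference between the core of compound 3 and the core of compound 2 is not broken down here.

Compound 4 `COc1ccc(-c2cc(/C=C/C(=O)c3cc(OC)c(OC)c(OC)c3)[nH]n2)cc1OC` has not yet been measured. It differs from compound 3 by hydrogen in place of methoxy on an aromatic carbon. Among the compounds with values here, this is the same kind of change as the one from compound 2 to compound 1, but not the same: in compound 4 the place is also meta to a methoxy group, which the place in compound 1 is not.

Resting on the step that the same kind of change made from compound 2 to compound 1, a step of a number 21 percentage points lower from compound 3 to compound 4 (beyond the scatter) is expected in this assay, taken as somewhat uncertain because the surroundings of the place differ. For compound 4 the expected value in this assay is 55%, between 40% and 72%.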

Compound 4, a percentage reported as activity, at one concentration (the size of the read-out at that concentration, not a potency): 57%
Compound 4: the middle estimate sits 2 percentage points below what was measured, within the range that was stated.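

In this assay, putting hydrogen in place of a methoxy group on an aromatic carbon made a step of a number 19 percentage points lower from compound 3 to compound 4 (beyond the scatter), so here too the compound without that methoxy group acted more strongly on the cells at the tested concentration. Set beside the earlier pair, the size of the step held up on the second core: the same change on two cores in this assay, a number 23 percentage points lower (beyond the scatter) from compound 2 to compound 1 and a number 19 percentage points lower (beyond the scatter) from compound 3 to compound 4, 4 percentage points apart, within the scatter of two such steps. This shows that, in these two pairs, the change carried over from one core to the other in the same direction and at a similar size, even though the place on the ring is not the same; it does not show that the change would do so on any other core or at any other methoxy group in the series, and two pairs read at a single concentration say nothing about potency or about why the number moves.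

The compounds shown leave open whether a hydroxyl group, a chlorine atom or an ethoxy group at this place would move the number in the same way as hydrogen. They also leave open how the amine of compound 1 and compound 2 compares with the methoxy groups that compound 3 and compound 4 carry in its stead, since no pair shown differs in that one place alone.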